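Aryl amide variation on a shared core: antiproliferative notes

The source may report more compounds than this note shows. Statements on the series, on what has been measured and on what is new or still open speak of the compounds shown alone.

Measured so far in a functional assay on AN3-CA cells (Homo sapiens) for antiproliferative activity, read by MTT assay, with a stated time of 72 h; on this read-out higher numbers stand for weaker inhibition and lower numbers for stronger inhibition:
- compound 1 `O=C(Nc1ccc(Cl)c(-c2nnc3c(Cl)cccn23)c1)c1ccccc1`: 67600 nM
- compound 2 `Cc1nc(C(=O)Nc2ccc(Cl)c(-c3nnc4c(Cl)cccn34)c2)cs1`: the value is a limit of this assay, > 100000 nM
- compound 3 `O=C(Nc1ccc(Cl)c(-c2nnc3c(Cl)cccn23)c1)c1cccc(Cl)c1`: 68400 nM

Compound 3 holds the highest of the two numbers given; its nearest neighbour is compound 1, the step of a 1.0-fold higher number from compound 1 to compound 3 (0.01 log units; within the scatter) being within the scatter. Compound 2 reaches only a limit (the limit of > 100000 nM in this assay, at which 1 of the 3 values shown sits), so the steps of an at least 1.4-fold higher number from compound 1 to compound 2 (0.17 log units; that floor lies within the scatter) and an at least 1.4-fold lower number from compound 2 to compound 3 (0.16 log units; that floor lies within the scatter) are floors that lie within the scatter. Every aryl variation on the carbonyl carbon seen so far thus leaves the read-out essentially unchanged.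

Compound 4 `O=C(Nc1ccc(Cl)c(-c2nnc3c(Cl)cccn23)c1)c1c(F)cccc1Cl` has not been measured. It differs from compound 3 by 2-chloro-6-fluorophenyl in place of 3-chlorophenyl on a carbonyl carbon. The bearing steps are the chloro-for-hydrogen change from compound 1 to compound 3 and the two aryl exchanges on the carbonyl carbon involving compound 2, all within the scatter. No step beyond the scatter is therefore expected in this assay for compound 4, in either direction; the estimated step is a 1.0-fold higher number from compound 3 to compound 4 (0.01 log units; within the scatter). Compound 4 is estimated at 70000 nM, with a range from 35000 nM to 140000 nM, and a fair chance that only a limit is returned.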

Compound 4, half-maximal inhibitory concentration: > 100000 nM
Compound 4 was reported as a limit; the forecaster's own chance of this, stated with the estimate: 35%; middle value at least 1.4-fold (0.15 log units) away from the limit.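

In this assay compound 4 returns only a limit, > 100000 nM. A limit on this carbonyl carbon is thus no longer confined to the 2-methyl-1,3-thiazol-4-yl group of compound 2, since it also appears with 2-chloro-6-fluorophenyl, a six-membered aromatic ring of carbon only. The readable steps are an at least 1.4-fold higher number from compound 3 to compound 4 (0.16 log units; that floor lies within the scatter) and an at least 1.4-fold higher number from compound 1 to compound 4 (0.17 log units; that floor lies within the scatter), so this change cannot be separated from 3-chlorophenyl or phenyl, and with limits on both sides the step between compound 2 and compound 4 cannot be read, leaving the upper end of the series defined only by: the limit of > 100000 nM in this assay, at which 2 of the 4 values shown sit.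

Still open is whether any group on this carbonyl carbon can move the read-out beyond the scatter, as no readable step among these compounds does so. An aminomethyl group or a carboxylic acid on the phenyl ring, or a cyclohexyl ring in place of the aromatic ring, would test this, and the compounds shown say nothing about any of them.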